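The source may hold more compounds than are shown below. What is called first, only, known or untested is meant among the compounds shown, and "the series" means these compounds.

The data come from an ADME assay on L02 cells (Homo sapiens) for antiproliferative activity, read by MTT assay, with a stated time of 48 h (a higher number here means a weaker inhibitor, a lower number a stronger inhibitor), in which two compounds have been run so far. Compound 1 `N#CC1=C(N)Oc2c(c3nc4ccccc4nc3c3ccccc23)C12C(=O)N(Cc1cnnn1-c1ccccc1Cl)c1ccccc12` returns only a limit of the assay, > 50000 nM, and not a number. Compound 2 `N#CC1=C(N)Oc2c(N)cc3nc4ccccc4nc3c2C12C(=O)N(Cc1cnnn1-c1ccccc1Br)c1ccccc12` returns a value of 29200 nM. Going by the values given here, that is the only number in hand, since the other result is a limit, as the limit of > 50000 nM in this assay, at which 1 of the 2 values shown sits, records. Among the compounds with values here, compound 2 therefore stands as the sole measured point, and with no second number to set against it, no step between measured compounds is known; the usual scatter of repeated measurements is the only guide to how far a single change might move a value here.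

Compound 3 `Cc1ccc(C)c(-n2nncc2CN2C(=O)C3(C(C#N)=C(N)Oc4c(N)cc5nc6ccccc6nc5c43)c3ccccc32)c1` has not yet been measured. It differs from compound 2 in one place: 2,5-dimethylphenyl in place of 2-bromophenyl on an aromatic nitrogen. Within the data shown here, the 2,5-dimethylphenyl and the 2-bromophenyl are close in size by the counted atoms, and no measured step shows what such a swap does in this assay. The expected step of a 1.0-fold higher number from compound 2 to compound 3 (0.01 log units; within the scatter) is none beyond the scatter. Compound 3 is estimated at 30000 nM, within a range from 10000 nM to 90000 nM, with a fair chance that this assay again returns only its limit.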

Compound 3, half-maximal inhibitory concentration: > 50000 nM
Compound 3: only a limit was reported; the forecaster's own chance of this, stated with the estimate: 35%; middle value at least 1.6-fold (0.22 log units) away from the limit.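

Going by these compounds alone, putting 2,5-dimethylphenyl in place of 2-bromophenyl on the aromatic nitrogen gives the first step at this position in this assay: an at least 1.7-fold higher number from compound 2 to compound 3 (0.23 log units; that floor lies within the scatter). That figure is a floor and not a size, so the change may have done no more than the scatter, or it may have done much more, and the data cannot separate the two. What the result does show is that this swap, which keeps a six-membered aromatic ring of carbon only and trades bromine for two methyl groups, gave no stronger inhibitor, and that most of the results shown now end at the same limit: the limit of > 50000 nM in this assay, at which 2 of the 3 values shown sit.

The compounds shown leave open whether the bromine, either methyl group or both methyl groups together account for the difference, which a phenyl ring with no substituent or with a single methyl group could help to separate. They also leave open what an amine or a carboxylic acid on this phenyl ring would do to the number.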